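A few compounds are considered here, and "the series" means these few. Any claim that something is new, unique, unknown or untested is made for them only; others in the source may bear on it.

Compound 1 `O=C(Nc1cc(C(F)(F)F)cc(C(F)(F)F)c1)C1CCc2ccccc2N1C(=O)c1ccc(Cl)cc1` carries a 4-chlorophenyl on a carbonyl carbon, and in a functional assay on MDA-MB-231 cells (Homo sapiens) for cytotoxicity, read by sulforhodamine B assay, with a stated time of 72 h (on this read-out higher numbers stand for weaker inhibition of growth and lower numbers for stronger inhibition of growth), compound 1 gives 2000 nM. Compound 2 `CC(=O)N1c2ccccc2CCC1C(=O)Nc1cc(C(F)(F)F)cc(C(F)(F)F)c1` has methyl in place of 4-chlorophenyl on a carbonyl carbon. In this assay compound 2 reaches only > 70000 nM, which is a limit of the assay and not a number. That change, an at least 35-fold higher number from compound 1 to compound 2 (1.54 log units; beyond the scatter), is large. Compound 3 `O=C(Nc1cc(C(F)(F)F)cc(C(F)(F)F)c1)C1CCc2ccccc2N1C(=O)c1cccc(Cl)c1` has 3-chlorophenyl in place of 4-chlorophenyl on a carbonyl carbon, and in this assay compound 3 gives 1190 nM, the lowest of the two numbers, with compound 1 nearest; the step of a 1.7-fold lower number from compound 1 to compound 3 (0.23 log units; within the scatter) stays within the scatter. Compound 4 `O=C(Nc1cc(C(F)(F)F)cc(C(F)(F)F)c1)C1CCc2ccccc2N1C(=O)c1ccccc1Cl` differs from compound 3 by 2-chlorophenyl in place of 3-chlorophenyl on a carbonyl carbon. The step that bears on this is a 1.7-fold lower number from compound 1 to compound 3 (0.23 log units; within the scatter), where exchanging one chlorophenyl for another chlorophenyl changed nothing beyond the scatter; the large step of an at least 58-fold lower number from compound 2 to compound 3 (1.76 log units; beyond the scatter) concerns exchanging methyl for an aryl group and does not apply here. The expected step in this assay, a 1.3-fold higher number from compound 3 to compound 4 (0.10 log units; within the scatter), is therefore small. Compound 4 is expected to give 1500 nM, between 500 nM and 5000 nM.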

Compound 4, concentration for 50% growth inhibition: 5250 nM
Compound 4: the middle estimate sits 3.5-fold (0.54 log units) below what was measured; measured number outside the range, above it.
By their numbers in this assay, from the lowest: compounds 3 and 1 (each within the scatter of the next); then compound 4. At a limit, above all of these: compound 2.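

Until now, swapping one chlorophenyl for another had seemed to change little, yet here the exchange gives a 4.4-fold higher number from compound 3 to compound 4 (0.64 log units; beyond the scatter), so in this assay the 2-chlorophenyl cannot be treated as equal to the 3-chlorophenyl on this carbonyl carbon. The comparison with the 4-chlorophenyl points the same way, with a 2.6-fold higher number from compound 1 to compound 4 (0.42 log units; beyond the scatter), so among the three chlorophenyl groups the 2-chlorophenyl alone stands apart. Even so, the 2-chlorophenyl still does far better than methyl, with an at least 13-fold lower number from compound 2 to compound 4 (1.12 log units; beyond the scatter), a step that starts from a limit of the assay and not from a number.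

Nothing among the results shown explains why the place of the chlorine on the ring matters here. As far as these compounds go, whether a 2-fluorophenyl or a 2-methoxyphenyl on the same carbonyl carbon would behave like compound 4 stays open.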